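Aryl swaps on the ring nitrogen in the aminothiophene series

The source may hold more compounds than are shown below. What is called first, only, known or untested is meant among the compounds shown, and "the series" means these compounds.

Three analogues of one core have numbers in a functional assay on CHO cells with adenosine receptor A1 (Homo sapiens) as the target, read by cAMP accumulation and immunoassay, with a stated time of 6 min, tested at 1 uM; a lower number here means a stronger effect, a higher number a weaker effect of the compound at the concentration tested. Compound 1 `COc1ccc(N2CCN(Cc3csc(N)c3C(=O)c3ccc(Cl)cc3)CC2)cc1` gives -15%. Compound 2 `Nc1scc(CN2CCN(c3ccccc3C(F)(F)F)CC2)c1C(=O)c1ccc(Cl)cc1` gives -39%. Compound 3 `Nc1scc(CN2CCN(c3ccc(OC(F)(F)F)cc3)CC2)c1C(=O)c1ccc(Cl)cc1` gives -51%, the lowest of the three numbers, set apart from both others beyond the scatter. The swaps of the aryl group on the amine nitrogen in the ring moved the read-out each time: a number 24 percentage points lower from compound 1 to compound 2 (beyond the scatter), a number 36 percentage points lower from compound 1 to compound 3 (beyond the scatter), a number 12 percentage points lower from compound 2 to compound 3 (beyond the scatter).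

Compound 4 `Nc1scc(CN2CCN(c3cccc(F)c3)CC2)c1C(=O)c1ccc(Cl)cc1` is not yet measured in this assay. It differs from compound 3 by 3-fluorophenyl in place of 4-(trifluoromethoxy)phenyl on an amine nitrogen in a ring. Among the compounds with values here, the steps that bear on it are the two aryl exchanges on that ring nitrogen, a number 24 percentage points lower from compound 1 to compound 2 (beyond the scatter) and a number 12 percentage points lower from compound 2 to compound 3 (beyond the scatter), both modest to large; the 4-(trifluoromethoxy)phenyl of compound 3 was the lowest in this set, so its removal is expected to raise the number back toward the values of compound 1 and compound 2. For compound 4 the expected step is a number 26 percentage points higher from compound 3 to compound 4 (beyond the scatter). Compound 4 is therefore estimated at -25%, with a range from -45% to -5%.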

Compound 4, a percentage reported as activity, at one concentration (the size of the read-out at that concentration, not a potency): -86%
For compound 4 the middle estimate is 61 percentage points above the measured one; the whole stated range lies above it.
By their numbers in this assay, from the lowest: compound 4; then compound 3; then compound 2; then compound 1.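

In this assay, within the data shown here, the aryl group on the ring nitrogen has more reach than the earlier compounds showed, whose largest step was a number 36 percentage points lower from compound 1 to compound 3 (beyond the scatter); 3-fluorophenyl gives a number 71 percentage points lower from compound 1 to compound 4 (beyond the scatter) and a number 47 percentage points lower from compound 2 to compound 4 (beyond the scatter). The exchange of 4-(trifluoromethoxy)phenyl, with 11 heavy atoms, for 3-fluorophenyl, with 7, gives a number 35 percentage points lower from compound 3 to compound 4 (beyond the scatter), so a low number at this position does not depend on the trifluoromethoxy group, and compound 4 now stands lowest of the four, beyond the scatter from each. Nothing available accounts for the size of these steps.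

The four compounds do not separate the effect of the fluorine from that of its place on the phenyl ring. Going by these compounds, how a chlorine, a nitrile or an amine on that phenyl ring would read remains open.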